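The source may hold more compounds than are shown below. What is called first, only, known or untested is meant among the compounds shown, and "the series" means these compounds.

Compound 1 `CC#CCn1c(N2CCC[C@@H](N)C2)nc2c1c(=O)n(Cc1ccc(Cl)cc1C(=O)O)c(=O)n2C` - 1.77 h
Compound 2 `CC#CCn1c(N2CCC[C@@H](N)C2)nc2c1c(=O)n(Cc1ccc(Cl)cc1C(=O)OCC)c(=O)n2C` - 8.02 h

In an ADME assay on the whole organism (Rattus norvegicus, strain Sprague-Dawley) for metabolic stability, read by LC-MS, with a stated time of 48 h, at a dose of 10 mg/kg by the oral route (on this read-out higher numbers stand for a longer-lived compound and lower numbers for a shorter-lived compound), compound 2 (8.02 h) is the higher of the two measured compounds, above compound 1 (1.77 h) by a gap beyond the scatter. Compound 3 `CC#CCn1c(N2CCC[C@@H](N)C2)nc2c1c(=O)n(Cc1ccc(Cl)cc1C(=O)OC)c(=O)n2C` is the next case. Against compound 2 it shows one difference (hydrogen in place of methyl on a saturated chain carbon bound to an oxygen next to a carbonyl group) with hydrogen in place of methyl on a saturated chain carbon bound to an oxygen next to a carbonyl group, so that ethoxycarbonyl becomes methoxycarbonyl.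

Among the measured compounds shown here, only one measured step bears on this (a 4.5-fold higher number from compound 1 to compound 2 (0.66 log units; beyond the scatter)) and it is modest in size yet beyond the scatter. That step put ethyl in place of hydrogen on an oxygen next to a carbonyl group, whereas compound 3 still carries a methyl there. Only a small part of that step is therefore expected to be given back, and perhaps nothing beyond the scatter. The expected change is a 1.3-fold lower number from compound 2 to compound 3 (0.13 log units; within the scatter) as a small downward move. For compound 3 the estimated half-life is 6 h and the expected range runs from 2.5 h to 13 h as the likely span.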

Compound 3, half-life: 10.1 h
Compound 3: middle estimate off by 1.7-fold (0.23 log units), on the low side; measured number inside the range.
By their numbers in this assay, from the lowest: compound 1; then compounds 2 and 3 (each within the scatter of the next).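

In this assay, the change from ethoxycarbonyl to methoxycarbonyl gives a 1.3-fold higher number from compound 2 to compound 3 (0.10 log units; within the scatter), so the compounds shown do not separate ethyl from methyl on this oxygen next to a carbonyl group. The comparison with the free carboxylic acid now rests on two groups rather than one: methyl in place of hydrogen gives a 5.7-fold higher number from compound 1 to compound 3 (0.76 log units; beyond the scatter), and ethyl in place of hydrogen gave a 4.5-fold higher number from compound 1 to compound 2 (0.66 log units; beyond the scatter), both beyond the scatter. Within this set of three, then, the clear difference lies between hydrogen and either alkyl group on this oxygen, while the size of that alkyl group, from methyl to ethyl, leaves no mark that can be read; no measurement is at hand that would explain either result.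

What the compounds shown leave open is whether this flat response continues with a longer chain such as propyl or butyl, or with a branched group such as isopropyl, on the same oxygen. They also leave open whether an amide in place of the ester would stand with the two alkyl esters or with the carboxylic acid in this assay.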